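A few compounds are considered here, and "the series" means these few. Any claim that something is new, unique, unknown or untested is made for them only; others in the source may bear on it.

Measured in a functional assay on MDA-MB-231 cells (Homo sapiens) for inhibition, read by MTT assay, with a stated time of 72 h; on this read-out lower numbers stand for stronger inhibition and higher numbers for weaker inhibition:
- Compound 1 `Cc1ccccc1-c1cc(C(=O)N2CCC3(CC2)CC(=O)c2nn(C(C)(C)C)cc2O3)c2ccccc2n1`: > 10000 nM (a limit)
- Compound 2 `CC(C)(C)n1cc2c(n1)C(=O)CC1(CCN(C(=O)c3cc(-c4ccccc4Cl)nc4ccccc34)CC1)O2`: > 10000 nM (a limit)
- Compound 3 `CC(C)(C)n1cc2c(n1)C(=O)CC1(CCN(C(=O)c3cc(-c4ccc(F)cc4)nc4ccccc34)CC1)O2`: > 10000 nM (a limit)

Compound 2 has no number on this read-out, only the limit of > 10000 nM. The same holds for its two neighbours, as the limit of > 10000 nM in this assay, at which 3 of the 3 values shown sit, shows, so nothing places compound 2 above or under them.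

Compound 4 `CC(C)(C)n1cc2c(n1)C(=O)CC1(CCN(C(=O)c3cc(-c4ccc(N)cc4)nc4ccccc34)CC1)O2` keeps the shared core and changes one group, on an aromatic carbon next to the ring nitrogen: 4-aminophenyl in place of 2-chlorophenyl, (4-aminophenyl in place of 2-chlorophenyl on an aromatic carbon).

The nearest measured change is a step that the two limits leave unreadable from compound 2 to compound 3, which replaces the same 2-chlorophenyl with 4-fluorophenyl. The other two changes at this carbon are a step that the two limits leave unreadable from compound 1 to compound 2 and a step that the two limits leave unreadable from compound 1 to compound 3. None of the three has a readable size, and none brought a compound off the limit of this assay.

These changes therefore give no size to carry over. The expectation is that the new group leaves compound 4 weak or only slightly stronger, as compound 3 stayed weak across a step that the two limits leave unreadable from compound 2 to compound 3. The step this implies is expected to be a step that the limit leaves unreadable from compound 2 to compound 4. A limit is again the likeliest report.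

For compound 4 the estimated value is 12000 nM, with an expected range from 3000 nM to 30000 nM.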

Compound 4, half-maximal inhibitory concentration: 4960 nM
Compound 4: the middle estimate sits 2.4-fold (0.38 log units) above what was measured; low and high end bracket the measured number.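

In this assay, compound 4 is the only one of the compounds shown that carries a number rather than a limit, so a change at this aromatic carbon next to the ring nitrogen can bring a compound onto the measurable scale. Compound 1, compound 2 and compound 3 each stand at a limit and not at a number, and the steps among them cannot be read: the limit of > 10000 nM in this assay, at which 3 of the 4 values shown sit. Placing 4-aminophenyl at this carbon gives an at least 2.0-fold lower number from compound 2 to compound 4 (0.30 log units; that floor lies within the scatter), an at least 2.0-fold lower number from compound 1 to compound 4 (0.30 log units; that floor lies within the scatter), and swapping amino for fluoro on the same phenyl ring gives an at least 2.0-fold lower number from compound 3 to compound 4 (0.30 log units; that floor lies within the scatter), so each step is known only as a floor, and no floor shows a change beyond the scatter.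

The compounds shown leave open whether the amino group itself matters, or whether a hydroxyl or an acetamide on the same phenyl ring would read the same. From the compounds shown here alone, they also leave open how large the true steps are, as the real values of compound 1, compound 2 and compound 3 remain unknown.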